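Swapping a Pentylselenyl Chain for Amino on a Fused Core

The source may hold more compounds than are shown below. What is called first, only, known or untested is meant among the compounds shown, and "the series" means these compounds.

Measured so far:
compound 1, `CCCCC[Se]c1nc([Se]CCCCC)c2cccnc2n1`: > 100000 nM
compound 2, `CSc1ccc(CNc2nc([SeH])nc3ccccc23)cc1`: 86300 nM
compound 3, `CCCCC[Se]c1nc(NCc2ccccc2)c2ccccc2n1`: > 100000 nM

All three were tested in an ADME assay on 184B5 cells (Homo sapiens) for cytotoxicity, read by MTT assay, with a stated time of 72 h; a higher number here means a weaker inhibitor of growth, a lower number a stronger inhibitor of growth. For compound 1 the result > 100000 nM is a limit of the assay rather than a number. Compound 1 therefore stands at the limit of > 100000 nM in this assay, at which 2 of the 3 values shown sit. For compound 3 the result > 100000 nM is likewise a limit. Compound 2, by contrast, gives a number in this assay, namely 86300 nM. No two of these compounds differ in only one place, so no measured step can be read from them, and none of the three can be called stronger or weaker than another.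

Compound 4, `CCCCC[Se]c1nc(N)c2cccnc2n1`, is not yet measured. It differs from compound 1 in one place: one nitrogen atom in place of a group of 6 heavy atoms (5 carbon, 1 selenium; no ring), on an aromatic carbon. Without a measured step of this kind to rest on, the expectation is that the step in this assay from compound 1 to compound 4 stays within the scatter, in no clear direction. Compound 4 is expected to give about 120000 nM, between 40000 nM and 400000 nM, with a good chance that only a limit is reported. The expected step is a step that the limit leaves unreadable from compound 1 to compound 4.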

Compound 4, concentration for total growth inhibition: 40200 nM
Beside the measured number, compound 4's estimate is 3.0-fold (0.47 log units) above it, and the stated range covers the measured number.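

In this assay, going by these compounds alone, putting an amino group in place of the group of 6 heavy atoms (5 carbon, 1 selenium), on an aromatic carbon next to the ring nitrogen, gives an at least 2.4-fold lower number from compound 1 to compound 4 (0.39 log units; beyond the scatter) and is the first step in this set that can be read at all. It shows that this position is not indifferent to what it carries: with amino there, the growth of these cells is inhibited more strongly than with the larger selenium-bearing group, and the result becomes a number rather than a limit. The step can be given only as a minimum, and its full size stays unknown, because the result for compound 1 is a limit and not a number: the limit of > 100000 nM in this assay, at which 2 of the 4 values shown sit.

The compounds shown leave open whether the stronger inhibition comes from the amino group entering or simply from the larger group leaving, a question that a hydroxyl group or a methylamino group on the same carbon could help to separate. From the compounds shown here alone, it also remains open whether the second group of 6 heavy atoms, which compound 4 still carries, matters in the same way.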